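Adding a hydroxy to compound 2

This account rests on a few compounds, and the source may have more. Where it says the series, first, only, none or still open, it means among the compounds named here.

Of the compounds shown here, three have been read so far in an ADME assay on BMEC cells (Bos taurus) for cytotoxicity, read by sulforhodamine B assay (a lower number here means a stronger inhibitor, a higher number a weaker inhibitor), and only two of them give numbers. Compound 1 (`COc1ccc(/C=C/c2cc(OC)c3ccoc3c2)cc1O`) stands at > 10000 nM as a limit of the assay. Compound 2 (`COc1ccc(/C=C\c2cc(OC)c3ccsc3c2)cc1`) gives 123 nM and holds the lower of the two numbers. Compound 3 (`COc1cc(/C=C\c2cc(O)c3ccoc3c2)cc(OC)c1`) gives 800 nM as the nearest value, and its gap to compound 2 lies beyond the scatter.

Compound 4 (`COc1ccc(/C=C\c2cc(OC)c3ccsc3c2)cc1O`) differs from compound 2 in one place: hydroxy in place of hydrogen on an aromatic carbon describes a hydroxy in place of hydrogen on an aromatic carbon, ortho to a methoxy group. Within the data shown here, compound 1 and compound 3 also carry a hydroxy and both sit higher than compound 2, but each differs from it in more than one place, so no measured step isolates this change.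

With a single small change to compound 2 at 123 nM as the starting point, a modest shift toward a lower number is expected, though the opposite direction cannot be excluded. The expected step is a 2.5-fold lower number from compound 2 to compound 4 (0.39 log units; beyond the scatter) as a rough estimate, not far beyond the scatter. For compound 4 the estimate is 50 nM within an expected range from 8 nM to 400 nM once measured.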

Compound 4, half-maximal inhibitory concentration: 17 nM
Compound 4: middle estimate off by 2.9-fold (0.47 log units), on the high side, within the range that was stated.
By their numbers in this assay, from the lowest: compound 4; then compound 2; then compound 3. At a limit, above all of these: compound 1.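

In this assay, among these compounds, the single change of a hydroxy in place of hydrogen, on the aromatic carbon ortho to a methoxy group, reads as a 7.2-fold lower number from compound 2 to compound 4 (0.86 log units; beyond the scatter) and is the first isolated step. Compound 1 and compound 3 also carry a hydroxy, but each differs from compound 2 in more than one place, so the steps to them cannot be read and they could not show what this position does on its own; here, with all else held constant, the added hydroxy goes with a lower number, not a higher one. No measurement shown gives a reason for this step.

Whether the shift belongs to the hydroxy itself stays open, since no other group at this carbon, such as a methoxy, an amine or a fluorine, appears among the compounds shown. Among the compounds shown here, also open is whether the same hydroxy would give a shift of similar size on a different core or with the other arrangement about the double bond, as no second pair differing in only this one place is available.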